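This account rests on a few compounds, and the source may have more. Where it says the series, first, only, none or still open, it means among the compounds named here.

Compound 3 `BrCCCc1ccc(-c2ccc(-c3ccc(-c4cccs4)s3)s2)s1` carries a 3-bromopropyl chain on the shared core. In an ADME assay on MDCK cells (Canis lupus familiaris) for cytotoxicity, read by MTT assay, with a stated time of 2 days (on this read-out lower numbers stand for higher toxicity in this test and higher numbers for lower toxicity in this test), compound 3 gives > 200000 nM, which is a limit of the assay and not a number. Compound 1 `NCCCc1ccc(-c2ccc(-c3ccc(-c4cccs4)s3)s2)s1` likewise sits at a limit, > 200000 nM. Compound 2 `[N-]=[N+]=NCCCCc1ccc(-c2ccc(-c3ccc(-c4cccs4)s3)s2)s1` has no result in this assay: "not determined" (no result reported). Among the compounds with values here, the step that the two limits leave unreadable from compound 1 to compound 3 is thus not readable, and the only evidence is the limit of > 200000 nM in this assay, at which 2 of the 3 values shown sit. Compound 4 `[N-]=[N+]=NCCCc1ccc(-c2ccc(-c3ccc(-c4cccs4)s3)s2)s1` differs from compound 3 in one place: azido in place of bromo on a saturated chain carbon, three bonds along the chain from an aromatic carbon. Within the data shown here, no measured step bears on this change, and with both readable compounds at the limit, no step beyond the scatter is expected in this assay. Compound 4 is estimated at 300000 nM (range 150000 nM to 1000000 nM), most probably reported again as a limit. The expected step that the limit leaves unreadable from compound 3 to compound 4 is essentially none.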

Compound 4, half-maximal cytotoxic concentration: > 100000 nM
Compound 4 ended at the assay's limit; the forecaster's own chance of this, stated with the estimate: 85%; the middle value lies beyond the limit too.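

The steps from compound 3 to compound 4 and from compound 1 to compound 4 cannot be read: all three compounds sit at limits, not numbers. The compounds shown leave open whether any chain on the shared core gives a measurable half-maximal cytotoxic concentration.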